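From bromo to chloro: what compound 4 may do

The compounds below may be only part of what the source reports. "The series", "measured", "known", "first", "only" and "open" are said of these compounds alone.

In a functional assay on NFS-60 cells (Mus musculus) for inhibition, with a stated time of 72 h (a lower number here means a stronger inhibitor of growth, a higher number a weaker inhibitor of growth), compound 1 `Nc1ncnc2c(C(=O)Nc3cccc4c3c(Br)nn4Cc3ccccc3)csc12` gives 1010 nM, compound 2 `Nc1ncnc2c(C(=O)Nc3cccc4c3c(Br)nn4Cc3cccc(Br)n3)csc12` gives 243 nM, and compound 3 `Cc1cccc(Cn2nc(Br)c3c(NC(=O)c4csc5c(N)ncnc45)cccc32)n1` gives 27.5 nM, the lowest of the three numbers. Compound 4 `Cc1cccc(Cn2nc(Cl)c3c(NC(=O)c4csc5c(N)ncnc45)cccc32)n1` has not yet been measured. It carries chloro in place of bromo on an aromatic carbon. The measured steps all lie elsewhere in the molecule: a 37-fold lower number from compound 1 to compound 3 (1.56 log units; beyond the scatter) and a 4.2-fold lower number from compound 1 to compound 2 (0.62 log units; beyond the scatter) replace phenyl, while an 8.8-fold lower number from compound 2 to compound 3 (0.95 log units; beyond the scatter) puts methyl in place of bromo on the pyridinyl group. None tests this bromo, so these sizes cannot be carried over, and no step beyond the scatter is expected in this assay. The expected step is a 1.2-fold higher number from compound 3 to compound 4 (0.07 log units; within the scatter). Compound 4 is estimated at 32 nM, within an expected range of 12 nM to 80 nM.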

Compound 4, concentration for 50% growth inhibition: 8 nM
Beside the measured number, compound 4's estimate is 4.0-fold (0.60 log units) above it; measured number below the stated range.
By their numbers in this assay, from the lowest: compound 4; then compound 3; then compound 2; then compound 1.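

For the compounds shown here, this is the only measured change at this carbon of the five-membered aromatic ring, and in this assay chloro in place of bromo gives a 3.4-fold lower number from compound 3 to compound 4 (0.54 log units; beyond the scatter). So a swap of one halogen atom for another, with no change in the count of heavy atoms, hydrogen-bond donors or acceptors, is enough to move the number beyond the scatter. No measurement shown accounts for this step.

Still open, on these data alone, is how fluoro, methyl or nitrile would behave on this carbon. Also open, as far as these compounds go, is whether chloro gives a step of similar size alongside the phenyl of compound 1 or the 6-bromopyridin-2-yl of compound 2.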